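A Chloro Step and Plasma Protein Binding

The source may hold more compounds than are shown below. What is called first, only, known or untested is meant among the compounds shown, and "the series" means these compounds.

Compound 1, `Nc1nccc(COc2ccc3nc(N[C@@H]4CCCC[C@H]4O)sc3c2)c1Cl`: in an ADME assay on a cell-free system (plasma, Rattus norvegicus, strain Sprague-Dawley) for protein binding, read by LC-MS, with a stated time of 5 h, tested at 5 uM, compound 1 gives > 99%, which is a limit of the assay.
Compound 2, `Nc1nccc(COc2cc(Cl)c3nc(N[C@@H]4CCCC[C@H]4O)sc3c2)c1Cl`: in this assay compound 2 gives > 99%, again a limit of the assay.
Compound 3, `COc1cc(OCc2ccnc(N)n2)cc2sc(N[C@H]3CCCC[C@@H]3O)nc12`: in this assay compound 3 gives 92.2%.

Compound 1 and compound 2 differ by chloro in place of hydrogen on an aromatic carbon. The step that the two limits leave unreadable from compound 1 to compound 2 cannot be sized, since both readings sit at the limit of > 99% in this assay, at which 2 of the 3 values shown sit. The difference between the core of compound 1 and the core of compound 3 is not broken down here.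

Compound 4, `COc1cc(OCc2ccnc(N)n2)c(Cl)c2sc(N[C@H]3CCCC[C@@H]3O)nc12`, has not yet been measured in this assay. It differs from compound 3 by chloro in place of hydrogen on an aromatic carbon. This is the same kind of change as that from compound 1 to compound 2, though the surroundings differ: in compound 4 the place is ortho to a (2-aminopyrimidin-4-yl)methoxy group and para to a methoxy group, whereas in compound 2 it is meta to a large group. The measured step gives no readable size, so the expectation rests on the value of compound 3, 92.2%, and on the unreadable step alone. Compound 4 is expected to give 96.5% in this assay, estimated between 91% and 99%. The expected step is a 2.2-fold lower unbound fraction from compound 3 to compound 4 (0.35 log units; beyond the scatter).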

Compound 4, plasma protein binding: 98.3%
The estimate for compound 4 lay 2.1-fold (0.31 log units) (unbound fraction) above the measured number; the measured number falls inside the stated range.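

In this assay, chloro in place of hydrogen on an aromatic carbon gives a 4.6-fold lower unbound fraction from compound 3 to compound 4 (0.66 log units; beyond the scatter), so on the core of compound 3 the change has a readable size that lies beyond the scatter. The same change on the core of compound 1 cannot be read, since compound 1 and compound 2 both stand at a limit: the limit of > 99% in this assay, at which 2 of the 4 values shown sit. The series therefore offers one readable step on one core, and it does not show that the change carries over from one core to another with the same size, or with any size at all.

The compounds shown leave open whether fluoro, methyl or a nitrile at this place on the core of compound 3 would shift plasma protein binding as chloro does. They also leave open what an amine or a carboxylic acid in place of the methoxy group would do to the reading, and how the chloro step behaves on a further core whose values stay clear of the limit.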